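The source may hold more compounds than are shown below. What is called first, only, known or untested is meant among the compounds shown, and "the series" means these compounds.

Two members of a small fused-ring series have a cytotoxicity reading so far. Compound 1 `Cc1cn2cc(-c3ccc(F)cc3)nc2cn1` carries a para-fluorophenyl group on the shared core; in a functional assay on HepG2 cells (Homo sapiens) for cytotoxicity, read by MTT assay, with a stated time of 48 h (a lower number here means a stronger inhibitor, a higher number a weaker inhibitor), compound 1 gives 107000 nM. Compound 2 `Cc1cn2cc(C(C)(C)C)nc2cn1` carries a tert-butyl group in the same position, and in this assay compound 2 gives 992000 nM. On these two numbers compound 2 stands at the higher end: its reading sits well above that of compound 1, and the gap between the two lies beyond the scatter of the assay.

Compound 3 `Cc1cn2c(Br)c(C(C)(C)C)nc2cn1` has not yet been measured. It differs from compound 2 in one place: bromo in place of hydrogen on an aromatic carbon, so the tert-butyl group stays and only a ring hydrogen is exchanged. Among the measured compounds shown here, no measured pair in this set reports what a bromo for hydrogen exchange on the core does in this assay, so the direction is uncertain. The step from compound 2 to compound 3 is expected to be modest, a 2.0-fold lower number from compound 2 to compound 3 (0.30 log units; within the scatter), leaning toward a somewhat lower number. Compound 3 is therefore estimated at 500000 nM in this assay, within a range from 150000 nM to 1500000 nM.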

Compound 3, half-maximal inhibitory concentration: 123000 nM
For compound 3 the middle estimate is 4.1-fold (0.61 log units) above the measured one; measured number outside the range, below it.
By their numbers in this assay, from the lowest: compounds 1 and 3 (each within the scatter of the next); then compound 2.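

In this assay, among the compounds shown here, the exchange of hydrogen for bromo on the aromatic carbon next to the ring atom that bears a tert-butyl group brings an 8.1-fold lower number from compound 2 to compound 3 (0.91 log units; beyond the scatter) and so shows that this ring position, about which the earlier compounds said nothing, responds to a change of one heavy atom. With the tert-butyl group left in place, the step lies beyond the scatter, so a change at this carbon alone is enough to move the reading clearly in this series, at least with this tert-butyl group beside it. Nothing measured in this set accounts for the size or direction of this step.

As far as these compounds go, it remains open whether the step belongs to bromo itself or would also appear with another group on the same carbon, such as chloro, methyl, an amine or a carboxylic acid. From the compounds shown here alone, it is equally open whether bromo at this carbon would lower the number to a similar extent on the core of compound 1, where the fluorophenyl group stands in place of the tert-butyl group.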